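The source may hold more compounds than are shown below. What is called first, only, known or untested is meant among the compounds shown, and "the series" means these compounds.

For the measured compounds named here, compound 2 `Cc1cc(NCc2ccccn2)n2ncc(C3=CCOCC3)c2n1` gives 171000 nM in a physicochemical assay for solubility, read by HPLC, using the shake flask method, measured as kinetic solubility, with a stated time of 2 h, at pH 7.4 (on this read-out lower numbers stand for lower solubility and higher numbers for higher solubility), the only number returned among the two measured compounds. Compound 1 `Cc1ccc(-c2cnn3c(NCc4ccccn4)cc(C)nc23)cc1` reaches only a limit of the assay, < 5000 nM. Going by the values given here, the step of an at least 34-fold higher number from compound 1 to compound 2 (1.53 log units; beyond the scatter) is the one measured change, and its size rests on (the limit of < 5000 nM in this assay, at which 1 of the 2 values shown sits), so its full extent is not known. Compound 3 `Cc1cc(NCc2ccccn2)n2ncc(-c3ccc(O)cc3)c2n1` is the next compound, not yet measured in this assay. It differs from compound 2 in one place: a group of 7 heavy atoms (6 carbon, 1 oxygen; one six-membered aromatic ring of carbon only) in place of a group of 6 heavy atoms (5 carbon, 1 oxygen; one six-membered non-aromatic ring with 1 hetero atom), on an aromatic carbon. The measured step bears on this change only in part, since it swapped an aromatic ring of carbon for the non-aromatic oxygen ring, whereas here an aromatic ring of carbon returns but now carries a hydroxyl with a hydrogen-bond donor. A step downward from compound 2 is therefore expected, though smaller than the step upward from compound 1 to compound 2, because an at least 34-fold higher number from compound 1 to compound 2 (1.53 log units; beyond the scatter) measured the loss of the aromatic ring alone, and the hydroxyl of compound 3 is expected to hold part of that gain. Compound 3 is estimated at 30000 nM, within 8000 nM to 100000 nM, a step of a 5.7-fold lower number from compound 2 to compound 3 (0.76 log units; beyond the scatter).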

Compound 3, solubility: 10900 nM
Compound 3: middle estimate off by 2.8-fold (0.44 log units), on the high side, and the stated range covers the measured number.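

In this assay, the aromatic carbon of the five-membered ring now responds strongly in both directions: the change back to an aromatic ring of carbon, this time as 4-hydroxyphenyl, gives a 16-fold lower number from compound 2 to compound 3 (1.20 log units; beyond the scatter), so the high number of compound 2 is largely lost even with a hydroxy on the new ring. A second comparison becomes available on that same aromatic ring, where hydroxy in place of methyl gives an at least 2.1-fold higher number from compound 1 to compound 3 (0.33 log units; beyond the scatter), so this smaller change also moves the number beyond the scatter, although far less than the exchange of the whole ring does. Compound 1 stands at a limit of the assay, so this last step gives only a minimum and its true size stays unknown: the limit of < 5000 nM in this assay, at which 1 of the 3 values shown sits.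

Going by these compounds, what a phenyl with no substituent would read stays open, so hydroxy and methyl cannot yet be set against a bare ring. Also open, on these data alone, are how an amine, a carboxylic acid or a methoxy in place of the hydroxy would read, and whether the double bond outside aromatic rings in compound 2 contributes to its number.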